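Acetoxy to diisopropylamino: working notes on the series

The source may hold more compounds than are shown below. What is called first, only, known or untested is meant among the compounds shown, and "the series" means these compounds.

In a functional assay on SMMC-7721 cells (Homo sapiens) for antiproliferative activity, read by MTT assay, with a stated time of 48 h (a lower number here means a stronger inhibitor, a higher number a weaker inhibitor), compound 1 `CC(=O)OC/C1=C/C[C@](C)(CCC=C(C)C)/C=C/[C@@H](OC(=O)C=C(C)C)[C@](C)(O)/C=C/C1=O` gives 2950 nM while compound 2 `CO[C@]1(C)/C=C/C(=O)/C(CO)=C\C[C@](C)(CCC=C(C)C)/C=C/[C@H]1OC(=O)C=C(C)C` gives 15800 nM and compound 3 `C=C1/C=C/C(=O)/C(CO)=C\C[C@](C)(CCC=C(C)C)/C=C/[C@H]1OC(=O)C=C(C)C` gives 4300 nM on the same read-out. Compound 1 and compound 3 lie within the scatter of each other. Compound 2 is the only one set apart, and its number is higher than that of compound 1 by a margin beyond the scatter. Compound 1 therefore stands at the low end of the measured numbers, level with compound 3.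

The next compound to read is compound 4 `CC(C)=CCC[C@]1(C)/C=C/[C@@H](OC(=O)C=C(C)C)[C@](C)(O)/C=C/C(=O)/C(CN(C(C)C)C(C)C)=C\C1` which has diisopropylamino in place of acetoxy on a saturated chain carbon bound to a double-bonded ring carbon with the rest of the core of compound 1 unchanged. For the measured compounds named here, no measured pair isolates this exchange, so the data offer no direct guide to its size or direction. The expectation is anchored on compound 1 at 2950 nM and the uncertainty is kept wide. The estimated step is a 1.0-fold higher number from compound 1 to compound 4 (0.01 log units; within the scatter) and so no change beyond the scatter is expected in this assay for this exchange. For compound 4 the estimated value is 3000 nM with an expected range from 900 nM to 10000 nM in this read-out.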

Compound 4, half-maximal inhibitory concentration: 340 nM
Compound 4: middle estimate off by 8.8-fold (0.95 log units), on the high side; the whole stated range lies above it.
By their numbers in this assay, from the lowest: compound 4; then compounds 1 and 3 (each within the scatter of the next); then compound 2.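

The exchange of acetoxy for diisopropylamino on a saturated chain carbon bound to a double-bonded ring carbon gives an 8.7-fold lower number from compound 1 to compound 4 (0.94 log units; beyond the scatter) in this assay with the rest of the core of compound 1 unchanged. For the compounds shown here, this is the first comparison that isolates one place, and it shows that this position does not require acetoxy for activity: a group of seven heavy atoms, carrying one nitrogen and no oxygen, can stand there and the number falls rather than rises. No supporting measurement bears on why the number falls, so the step stands as an observation on this single pair.

As far as these compounds go, whether the step is particular to diisopropylamino or is shared by a smaller amine such as dimethylamino, or by a cyclic amine such as morpholine, remains open. Also open, from the compounds shown here alone, is how a carboxylic acid on this same carbon would read in this assay and whether the step would hold in a second cell line.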